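The compounds below may be only part of what the source reports. "The series", "measured", "known", "first", "only" and "open" are said of these compounds alone.

Working notes on the series in a functional assay for antagonist activity at transient receptor potential cation channel subfamily V member 1 (Homo sapiens), read by FLIPR; on this read-out higher numbers stand for weaker inhibition and lower numbers for stronger inhibition.

Two compounds carry numbers. Compound 1 `C[C@@H]1CN(c2ncccc2C(F)(F)F)CCN1C(=O)Nc1ccc(C(F)(F)F)cc1` gives 17 nM in this assay. Going by the values given here, compound 2 `O=C(Nc1ccccc1)c1ccc(-c2ncccc2C(F)(F)F)cc1` differs from compound 1 in its core and its linkage, so no single step joins the two. For compound 2 this assay reports only a limit, > 4000 nM, not a number. Among the values at hand, (the limit of > 4000 nM in this assay, at which 1 of the 2 values shown sits), so compound 2 stands at the weak end of what the assay can read, with no measured number to place it more exactly.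

Compound 3 `N#Cc1ccc(NC(=O)c2ccc(-c3ncccc3C(F)(F)F)cc2)cc1` is not yet measured. It differs from compound 2 by one change: cyano in place of hydrogen on an aromatic carbon, para to a large group. Among the compounds with values here, no step between measured compounds matches this change, so its size in this assay rests on no direct precedent. The expectation is a step of an at least 1.3-fold lower number from compound 2 to compound 3 (0.12 log units; that floor lies within the scatter), small and most likely not beyond the scatter, since compound 2 gave only a limit. Compound 3 is estimated at 3000 nM, within a range of 800 nM to 10000 nM, with a fair chance that this assay again reports only a limit.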

Compound 3, half-maximal inhibitory concentration: 417 nM
Beside the measured number, compound 3's estimate is 7.2-fold (0.86 log units) above it; the whole stated range lies above it.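

The change from anilino to (4-cyanophenyl)amino gives an at least 9.5-fold lower number from compound 2 to compound 3 (0.98 log units; beyond the scatter) in this assay, so this place on the ring, para to a large group, responds to substitution on this core. Going by these compounds alone, compound 3, at 417 nM, gives the first measured number for this core. The size of the step is a floor rather than a measured gap, since compound 2 carries only a limit: the limit of > 4000 nM in this assay, at which 1 of the 3 values shown sits.

As far as these compounds go, what a carboxylic acid, an amine or a chlorine atom at this same place would do remains open, so the step cannot yet be tied to cyano as such rather than to any replacement of hydrogen there. Within the data shown here, also open is how the core of compound 3 relates to that of compound 1, because the two differ in more than one place and no single step joins them, which leaves unclear which part of that difference matters in this assay.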